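The source may hold more compounds than are shown below. What is called first, only, known or untested is meant among the compounds shown, and "the series" means these compounds.

Compound 1 `O=C(O)c1ccc(C(=O)/C=C/c2ccc3c(c2)B(O)OC3)cc1` is one of three analogues sharing a core in which the remote ring carries a varying substituent. In an ADME assay on L929 cells (Mus musculus) for cytotoxicity, read by resazurin assay, with a stated time of 72 h (on this read-out lower numbers stand for stronger inhibition and higher numbers for weaker inhibition), compound 1 gives only the limit > 10 ug/mL, not a number. Compound 3 `COc1cccc(C(=O)/C=C/c2ccc3c(c2)B(O)OC3)c1` likewise sits at the limit > 10 ug/mL in this assay. Among the compounds with values here, compound 2 `COCOc1ccccc1C(=O)/C=C/c1ccc2c(c1)B(O)OC2` is the one analogue with a number, giving 9.02 ug/mL in this assay. So compound 1 stands at the limit of > 10 ug/mL in this assay, at which 2 of the 3 values shown sit. Compound 4 `CCc1ccc(C(=O)/C=C/c2ccc3c(c2)B(O)OC3)cc1` differs from compound 1 by ethyl in place of carboxy on an aromatic carbon. Since compound 1 offers only a limit, no measured step sizes the change; in this assay the value of compound 4 is expected to fall from the limit of compound 1 by a modest amount, an at least 1.2-fold lower number from compound 1 to compound 4 (0.09 log units; that floor lies within the scatter), comparable to the scatter. Compound 4 is therefore estimated at 8 ug/mL, within 3 ug/mL to 20 ug/mL.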

Compound 4, half-maximal inhibitory concentration: > 10 ug/mL
Compound 4: only a limit was reported; the forecaster's own chance of this, stated with the estimate: 45%; at least 1.2-fold (0.09 log units) between middle value and limit.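

In this assay compound 4 gives only a limit, > 10 ug/mL, and compound 1 is also reported only as a limit, so no step can be read between compound 1 and compound 4. The compounds shown leave open whether ethyl in place of carboxy on an aromatic carbon changes the value in this assay at all.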